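A Methoxy Swap Against an Unbroken Limit

The source may report more compounds than this note shows. Statements on the series, on what has been measured and on what is new or still open speak of the compounds shown alone.

- Compound 1 `CCCCOc1cccc(-c2[nH]c3cc(OC)ccc3c(=O)c2C(=O)OCC)c1` gives > 22000 nM (a limit)
- Compound 2 `CCOC(=O)c1c(-c2cccc(F)c2)[nH]c2cc(OC)ccc2c1=O` gives > 22000 nM (a limit)
- Compound 3 `CCOC(=O)c1c(-c2cccc(Cl)c2)[nH]c2cc(OC)ccc2c1=O` gives > 22000 nM (a limit)

In an ADME assay on HEK293 cells (Homo sapiens) for cytotoxicity, read by luminescence, with a stated time of 72 h (a lower number here means that less compound is needed, a higher number that more compound is needed for the effect), compound 3 gives > 22000 nM as a limit and not as a number. The other two compounds also give limits, so all three share the limit of > 22000 nM in this assay, at which 3 of the 3 values shown sit, and none can be ranked against another.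

Compound 4 `CCOC(=O)c1c(-c2cccc(Cl)c2)[nH]c2cc(C(F)(F)F)ccc2c1=O` keeps the chloro group of compound 3 and differs at one place on the shared core: trifluoromethyl in place of methoxy on an aromatic carbon.

Three steps have been measured, namely a step that the two limits leave unreadable from compound 1 to compound 2 and a step that the two limits leave unreadable from compound 1 to compound 3 and also a step that the two limits leave unreadable from compound 2 to compound 3 in the same assay. All three change a different place in the molecule, and none has a readable size, so they offer only weak guidance here. Going by these compounds, all three measured compounds carry the methoxy group, so its replacement is untested.

Among the measured compounds shown here, no step of readable size or known direction is therefore expected in this assay on this evidence. This expectation rests on compound 3 and its limit of > 22000 nM in this read-out. The expected change is a number no higher from compound 3 to compound 4 (the limit leaves the size open) and it may well stay unreadable. Compound 4 is estimated at 22000 nM with an expected range from 9000 nM to 40000 nM in this read-out.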

Compound 4, half-maximal effective concentration: > 22000 nM
Compound 4 gave a limit, no number; the forecaster's own chance of this, stated with the estimate: 75%; the middle value sits exactly at the limit.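

Compound 3 and compound 4 each give only a limit in this assay, so the swap of methoxy for trifluoromethyl yields no step that can be read: the limit of > 22000 nM in this assay, at which 4 of the 4 values shown sit.

The compounds shown leave open how much of any of them would be needed for the effect in this assay, and whether any change to the shared core would give a real number.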